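Compound 3: cytotoxicity expected near the assay limit

The compounds below may be only part of what the source reports. "The series", "measured", "known", "first", "only" and "open" are said of these compounds alone.

Among the measured compounds shown here, only two compounds have been measured so far. In an ADME assay on HOS cells (Homo sapiens) for cytotoxicity (a lower number here means that less compound is tolerated, a higher number that more compound is tolerated), compound 1 `CN(Cc1nc2ccccc2n1CCCNC(=O)C(F)(F)F)C1CCCc2cccnc21` gives 10400 nM as a numerical read-out. Compound 2 `CN(Cc1nc2cccc(C(=O)NCCCN)c2[nH]1)C1CCCc2cccnc21` gives > 20000 nM in this assay and this is a limit of the assay, not a number. Compound 2 therefore offers no exact starting value.

Compound 3 `CN(Cc1nc2cccc(CN)c2[nH]1)C1CCCc2cccnc21` carries aminomethyl in place of (3-aminopropyl)carbamoyl on an aromatic carbon and is otherwise the same as compound 2. For the measured compounds named here, no measured step between compounds differing in one place is available to size this change. The working expectation in this assay is therefore no step beyond the scatter, with any shift more likely towards less compound tolerated. The estimated step of an at least 1.1-fold lower number from compound 2 to compound 3 (0.04 log units; that floor lies within the scatter) is expected to be small. The low end of the range allows for a result near compound 1 at 10400 nM in the same read-out. Compound 3 is estimated at 18000 nM with an expected range of 8000 nM to 30000 nM for this measurement.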

Compound 3, half-maximal cytotoxic concentration: > 20000 nM
Compound 3 was reported as a limit (the forecaster's own chance of this, stated with the estimate: 60%); middle value at least 1.1-fold (0.04 log units) from the limit.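

No step can be read from compound 2 to compound 3 in this assay, because both compounds stand at the same limit of the assay rather than at numbers: the limit of > 20000 nM in this assay, at which 2 of the 3 values shown sit.

The compounds shown leave open how much compound is tolerated for compound 2 and compound 3, and so whether aminomethyl in place of (3-aminopropyl)carbamoyl changes the read-out at all.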